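The source may report more compounds than this note shows. Statements on the series, on what has been measured and on what is new or still open speak of the compounds shown alone.

The measured compounds:
compound 1, `O=C(Nc1ccc(Oc2ccnc3[nH]ccc23)c(F)c1)c1ccc(-c2ccccc2)cn1`, gives 1250 nM in a functional assay on A549 cells (Homo sapiens) for cytotoxicity, read by MTT assay, with a stated time of 72 h; on this read-out lower numbers stand for stronger inhibition and higher numbers for weaker inhibition;
compound 2, `Cc1ccc(-c2ccc(C(=O)Nc3ccc(Oc4ccnc5[nH]ccc45)c(F)c3)nc2)cc1`, gives 2300 nM;
compound 3, `Cc1ccc(-c2ccnc(C(=O)Nc3ccc(Oc4ccnc5[nH]ccc45)c(F)c3)c2)cc1`, gives 3120 nM.

Compound 1 and compound 2 differ in one place: methyl in place of hydrogen on an aromatic carbon. This change gave a 1.8-fold higher number from compound 1 to compound 2 (0.26 log units; within the scatter), so the two values cannot be told apart. Compound 3 carries another core; the difference between the core of compound 1 and that of compound 3 is not broken down here. What the numbers show is that compound 3 holds the highest of the three values, that its gap to compound 1 lies beyond the scatter, and that its gap to compound 2 lies within it.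

Compound 4, `Cc1ccc(-c2ccnc(C(=O)Nc3ccc(Oc4ccnc5[nH]ccc45)c(F)c3)c2)c(C)c1`, has not yet been measured in this assay. It differs from compound 3 in one place: methyl in place of hydrogen on an aromatic carbon. This is the same kind of change as that from compound 1 to compound 2, but not the same: there the entering methyl sat para to a large group, here it sits ortho to a large group and meta to a methyl group. Among the measured compounds shown here, the earlier step is the only guide, and because a 1.8-fold higher number from compound 1 to compound 2 (0.26 log units; within the scatter), compound 4 is expected to stay close to compound 3. The step this expectation means is a 1.1-fold higher number from compound 3 to compound 4 (0.05 log units; within the scatter). Compound 4 is therefore estimated at 3500 nM. Its expected range runs from 1600 nM to 8000 nM. The range is wide: this kind of change appears only once in these data, and that once in another core.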

Compound 4, half-maximal inhibitory concentration: 4350 nM
The estimate for compound 4 lay 1.2-fold (0.09 log units) below the measured number; measured number inside the range.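

In this assay, turning the 4-methylphenyl group into 2,4-dimethylphenyl gave a 1.4-fold higher number from compound 3 to compound 4 (0.14 log units; within the scatter), so the two values cannot be told apart. Set beside the earlier step, the methyl change reads alike on both cores: the same change on two cores in this assay, a 1.8-fold higher number (0.26 log units; within the scatter) from compound 1 to compound 2 and a 1.4-fold higher number (0.14 log units; within the scatter) from compound 3 to compound 4, 1.3-fold (0.12 log units) apart, within the scatter of two such steps. Among the compounds shown here, this shows that on these two cores the added methyl produced no step that can be resolved from the scatter, and that the two cores do not separate in their response to it; it does not show that the methyl has a real effect of its own on either core, that the two cores respond identically, or that the same result would hold on any other core, and the entering methyl also stands in a different place in each pair.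

The compounds shown leave open how this group would read if it carried something other than hydrogen or methyl, such as a methoxy group, a chlorine atom, an amine or a carboxylic acid. They also leave open whether a longer chain such as ethyl in the place of the entering methyl would give a step that rises beyond the scatter.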